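Moving the Fluoro Group on the Phenyl Ring

A few compounds are considered here, and "the series" means these few. Any claim that something is new, unique, unknown or untested is made for them only; others in the source may bear on it.

Measured in a functional assay on HepG2 cells (Homo sapiens) for inhibition, read by MTT assay, with a stated time of 24 h; a higher number here means a weaker inhibitor, a lower number a stronger inhibitor:
- compound 1 `CC1(C)[C@H]2CC[C@]1(C)N(Cc1cn(-c3ccccc3Br)nn1)C(=O)C2`: 150 nM
- compound 2 `CC1(C)[C@H]2CC[C@]1(C)N(Cc1cn(-c3ccccc3F)nn1)C(=O)C2`: 60 nM

Compound 2 has the lower of the two numbers, which makes it the stronger inhibitor so far. Compound 3 `CC1(C)[C@H]2CC[C@]1(C)N(Cc1cn(-c3ccc(F)cc3)nn1)C(=O)C2` carries 4-fluorophenyl in place of 2-fluorophenyl on an aromatic nitrogen. For the measured compounds named here, the only measured step, a 2.5-fold lower number from compound 1 to compound 2 (0.40 log units; beyond the scatter), replaces bromo with fluoro on an aromatic carbon. Going by the values given here, it offers a rough size for a change on this ring, but no direction for the new one, as no measured pair shows the fluoro group in a different place. The expectation in this assay is therefore no step beyond the scatter, and the estimated step is a 1.3-fold higher number from compound 2 to compound 3 (0.12 log units; within the scatter). For compound 3 the estimated value is 80 nM, with an expected range of 25 nM to 250 nM.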

Compound 3, half-maximal inhibitory concentration: 90 nM
Compound 3: the middle estimate sits 1.1-fold (0.05 log units) below what was measured; measured number inside the range.
By their numbers in this assay, from the lowest: compounds 2, 3 and 1 (each within the scatter of the next, the first and the last beyond it).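

In this assay, 4-fluorophenyl in place of 2-fluorophenyl gives a 1.5-fold higher number from compound 2 to compound 3 (0.18 log units; within the scatter), so this first look at where the fluoro group sits shows no difference that can be told from the scatter. Changing both the halogen and its place, 4-fluorophenyl in place of 2-bromophenyl, gives a 1.7-fold lower number from compound 1 to compound 3 (0.22 log units; within the scatter), which also cannot be told from the scatter. Nothing measured here explains these results. Still open, from the compounds shown here alone, is whether a methoxy group, an amine or a carboxylic acid in place of the fluoro group of compound 3 would move the number beyond the scatter.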